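This account rests on a few compounds, and the source may have more. Where it says the series, first, only, none or still open, it means among the compounds named here.

Compound 1 `CNc1nc(NCC(C)(C)C)cc(-c2ccccn2)n1` gives 365 nM in a functional assay on HEK293 cells for agonist activity at G-protein coupled receptor 39 (Mus musculus), read by inositol phosphate accumulation (a lower number here means that less compound is needed, a higher number that more compound is needed for the effect), the highest of the two numbers in hand. Compound 2 `Cc1nc(NCc2ccc(Cl)cc2)cc(-c2ccccn2)n1` gives 17 nM in this assay, a lower number by a margin beyond the usual scatter; the two compounds differ in more than one place, so no single structural step accounts for that gap. Compound 3 `CNc1nc(NCC2CC2)cc(-c2ccccn2)n1` is not yet measured. It differs from compound 1 in one place: cyclopropyl in place of tert-butyl on a saturated chain carbon bound to a nitrogen on an aromatic ring. Cut one bond further out the change reads neopentyl to cyclopropylmethyl, that is neopentylamino to (cyclopropylmethyl)amino. Nothing in hand isolates this change, so the size of the step from compound 1 to compound 3 in this assay is open. The expected step is a 1.2-fold higher number from compound 1 to compound 3 (0.09 log units; within the scatter), judged to stay within the scatter in either direction. Compound 3 is estimated at 450 nM, with a range of 150 nM to 1400 nM.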

Compound 3, half-maximal effective concentration: 115 nM
For compound 3 the middle estimate is 3.9-fold (0.59 log units) above the measured one; measured number below the stated range.
By their numbers in this assay, from the lowest: compound 2; then compound 3; then compound 1.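

Within the data shown here, replacing tert-butyl with cyclopropyl on a saturated chain carbon bound to a nitrogen on an aromatic ring gives a 3.2-fold lower number from compound 1 to compound 3 (0.50 log units; beyond the scatter) in this assay and is the first single-place comparison. It shows that this position responds to a small change in the group: one heavy atom fewer and a three-membered ring in place of an open branch are enough to move the number beyond the scatter. Nothing in hand explains this shift.

Among these compounds, the single step changes atom count and ring content together, so their contributions cannot be separated; cyclobutyl or isobutyl at the same place would be needed to tell them apart. On these data alone, how far this trend extends also remains open, including whether an aromatic group such as benzyl would continue it on the core of compound 3.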